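The source may report more compounds than this note shows. Statements on the series, on what has been measured and on what is new or still open speak of the compounds shown alone.

Working notes on the series.

Compound 2, `Fc1ccccc1-c1nc(Cc2c[nH]c3ccccc23)no1`, gives in an ADME assay on cells (Splenocyte, Mus musculus, strain BALB/c) for cytotoxicity, read by CCK-8 assay, with a stated time of 48 h (a higher number here means that more compound is tolerated, a lower number that less compound is tolerated), a value of > 50000 nM, which is a limit of the assay and not a number. Compound 1, `COc1ccccc1-c1nc(Cc2c[nH]c3ccccc23)no1`, gives in this assay a value of 42200 nM. Among the measured compounds shown here, the one measured step, an at least 1.1-fold higher number from compound 1 to compound 2 (0.07 log units; that floor lies within the scatter), is small and runs into (the limit of > 50000 nM in this assay, at which 1 of the 2 values shown sits), so only the floor of that step is known.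

Compound 3, `CCCCc1nc(Cc2c[nH]c3ccccc23)no1`, differs from compound 2 as follows: butyl in place of 2-fluorophenyl on an aromatic carbon. For the measured compounds named here, no measured step covers an exchange of an aromatic ring for a chain at this position; the only step measured alters a substituent on the aromatic ring that leaves. Given that compound 2 stands at the limit and compound 1 sits near it, no step beyond the scatter is expected in this assay in either direction. For compound 3 the value in this assay is therefore estimated at 50000 nM, within 20000 nM to 120000 nM, which is an expected step of a number no higher from compound 2 to compound 3 (the limit leaves the size open).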

Compound 3, half-maximal cytotoxic concentration: > 50000 nM
Compound 3 ended at the assay's limit; the forecaster's own chance of this, stated with the estimate: 55%; the middle value lies on the limit itself.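

Among the compounds shown here, no step from compound 2 to compound 3 can be read in this assay, as both compounds stand at a limit and not at a number: the limit of > 50000 nM in this assay, at which 2 of the 3 values shown sit.

As far as these compounds go, whether butyl in place of 2-fluorophenyl changes the number in this assay at all remains open, as does how far compound 2 and compound 3 lie past that limit.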